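The source may hold more compounds than are shown below. What is called first, only, known or untested is meant among the compounds shown, and "the series" means these compounds.

Three compounds share one core and differ only in what sits on the far aromatic ring. Compound 1 `CC(=O)NCc1ccccc1-c1ccc(COC2CC[C@H](N3CCCCCC3)[C@H]2OC/C=C\CCC(=O)O)cc1` carries an acetamidomethyl group there; in a functional assay on blood for antagonist activity at thromboxane A2 receptor (Homo sapiens) (a higher number here means weaker binding, a lower number tighter binding), compound 1 gives 25.1 nM. Compound 2 `CS(=O)(=O)Nc1cccc(-c2ccc(COC3CC[C@H](N4CCCCCC4)[C@H]3OC/C=C\CCC(=O)O)cc2)c1` carries a methanesulfonamido group instead, and in this assay compound 2 gives 12.6 nM. Compound 3 `O=C(O)CC/C=C\CO[C@H]1C(OCc2ccc(-c3ccccc3)cc2)CC[C@@H]1N1CCCCCC1` has a plain phenyl, and in this assay compound 3 gives 12.6 nM. Compound 3 thus sits level with compound 2, and the two together show the lowest numbers of the three, while compound 1 is a 2.0-fold lower number from compound 1 to compound 3 (0.30 log units; within the scatter); the other comparisons read a 2.0-fold lower number from compound 1 to compound 2 (0.30 log units; within the scatter) and no change at the digits printed from compound 2 to compound 3 (within the scatter), so none of the three stands apart from the others beyond the scatter.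

Compound 4 `O=C(O)CC/C=C\CO[C@H]1C(OCc2ccc(-c3ccccc3CCO)cc2)CC[C@@H]1N1CCCCCC1` returns to the plain phenyl of compound 3 and adds one group: 2-hydroxyethyl in place of hydrogen on an aromatic carbon, so that phenyl becomes 2-(2-hydroxyethyl)phenyl. Among the measured compounds shown here, the steps that bear on this are the two that remove a group from that same ring, a 2.0-fold lower number from compound 1 to compound 3 (0.30 log units; within the scatter) and no change at the digits printed from compound 2 to compound 3 (within the scatter), both within the scatter. Adding a group to that ring has so far moved nothing beyond the scatter, so no step beyond the scatter is expected in this assay either, in either direction. The expected step is a 1.2-fold higher number from compound 3 to compound 4 (0.08 log units; within the scatter), and compound 4 is estimated at 15 nM, with a range from 5 nM to 45 nM.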

Compound 4, dissociation constant: 2 nM
The estimate for compound 4 lay 7.5-fold (0.88 log units) above the measured number; the measured number lies below the stated range.
By their numbers in this assay, from the lowest: compound 4; then compounds 2, 3 and 1 (each within the scatter of the next).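

Among the compounds shown here, compound 4 shows that this ring can move the number after all: adding 2-hydroxyethyl to the plain phenyl gives a 6.3-fold lower number from compound 3 to compound 4 (0.80 log units; beyond the scatter) in this assay, the first step in this set to pass beyond the scatter. The comparisons with the two substituted rings point the same way, with a 6.3-fold lower number from compound 2 to compound 4 (0.80 log units; beyond the scatter) where 2-(2-hydroxyethyl)phenyl takes the place of 3-(methanesulfonamido)phenyl, and a 13-fold lower number from compound 1 to compound 4 (1.10 log units; beyond the scatter) where hydroxymethyl takes the place of acetamido on the chain, so the gain depends on what the group is and not merely on a group being present, since the 2-(acetamidomethyl)phenyl of compound 1 brought no step beyond the scatter relative to the plain phenyl of compound 3. Nothing available here accounts for why the 2-hydroxyethyl group has this effect.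

The compounds shown leave open whether the hydroxyl end of the chain is what counts, which a plain ethyl, a methoxyethyl, a 2-aminoethyl or a carboxylic acid in its place could test. They also leave open how the number responds to chain length, as with a 3-hydroxypropyl group, and whether 2-hydroxyethyl elsewhere on the ring gives a similar step.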